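Swapping a phenol for a nitrile on a diyne scaffold

A few compounds are considered here, and "the series" means these few. Any claim that something is new, unique, unknown or untested is made for them only; others in the source may bear on it.

Compound 1 `OCCCCC#Cc1ccccc1C#Cc1ccccn1` is the starting point of this small series. In a functional assay on DU-145 cells (Homo sapiens) for cytotoxicity (a higher number here means a weaker inhibitor of growth, a lower number a stronger inhibitor of growth), compound 1 gives 9800 nM. Compound 2 `OCCCCC#Cc1ccccc1C#Cc1ccc(O)cc1` keeps the shared core and gives 16800 nM in this assay. Within the data shown here, the only measured step, a 1.7-fold higher number from compound 1 to compound 2 (0.23 log units; within the scatter), is within the scatter, so compound 2 stands at the same level as compound 1, the only other number available, and neither can be called the stronger.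

Compound 3 `N#Cc1ccc(C#Cc2ccccc2C#CCCCCO)cc1` is not yet measured. It differs from compound 2 by cyano in place of hydroxy on an aromatic carbon. Among the measured compounds shown here, the one measured step, from compound 1 to compound 2, exchanged the whole aromatic ring on the triple-bonded carbon and still moved the number only within the scatter. That step bears only loosely on the present change, which keeps the ring and alters a single group on it, but it gives no sign that this part of the molecule shifts the numbers strongly. The expectation for compound 3 in this assay is therefore a step of a 1.1-fold lower number from compound 2 to compound 3 (0.05 log units; within the scatter), which is none beyond the scatter. Compound 3 is thus estimated at 15000 nM, with a range from 5000 nM to 45000 nM.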

Compound 3, concentration for 50% growth inhibition: 16000 nM
The estimate for compound 3 lay 1.1-fold (0.03 log units) below the measured number; the range from low to high includes it.
By their numbers in this assay, from the lowest: compounds 1, 3 and 2 (each within the scatter of the next).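

In this assay, cyano in place of hydroxy on the aromatic carbon gives a 1.1-fold lower number from compound 2 to compound 3 (0.02 log units; within the scatter), so this exchange leaves the number level. Among these compounds, this is the first comparison in which the ring stays and only the group on it is exchanged, which the earlier step, with its change of the whole aromatic ring, could not show on its own: a hydroxy with one hydrogen-bond donor and a cyano with none give numbers that cannot be told apart in this assay, so at this place on these compounds the hydroxy's donor is not needed to hold the number at this level. No measured evidence is available to explain why the two groups match here.

As far as these compounds go, both groups tried on this ring carbon leave the number at the same level, so it remains open whether an amine or a carboxylic acid at this place, or a group on another carbon of the ring, would move it beyond the scatter. From the compounds shown here alone, it is equally open whether the far end of the molecule matters more, for instance whether a longer chain in place of the one ending in hydroxy would shift the number in this assay.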